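The source may report more compounds than this note shows. Statements on the series, on what has been measured and on what is new or still open speak of the compounds shown alone.

Of the compounds shown here, three that share one core have been measured in an assay on HL-60 cells for agonist activity at vitamin D3 receptor (Homo sapiens), read by microscopy, with a stated time of 96 h; on this read-out higher numbers stand for an effect only at larger amounts of compound and lower numbers for an effect already at smaller amounts. Compound 1 `CCn1c(C(=O)NCCN)ccc1C(CC)(CC)c1ccc(OCC(=O)C(C)(C)C)c(C)c1` carries a (2-aminoethyl)amino group on the carbonyl carbon and gives 120 nM. Compound 2 `C#CCCOC(=O)c1ccc(C(CC)(CC)c2ccc(OCC(=O)C(C)(C)C)c(C)c2)n1CC` carries (but-3-yn-1-yl)oxy in that place and gives 28800 nM, while compound 3 `CCOC(=O)c1ccc(OC(=O)c2ccc(C(CC)(CC)c3ccc(OCC(=O)C(C)(C)C)c(C)c3)n2CC)cc1` carries 4-(ethoxycarbonyl)phenoxy there and gives 45600 nM. Compound 3 thus stands at the upper end of the three numbers: the step of a 380-fold higher number from compound 1 to compound 3 (2.58 log units; beyond the scatter) is large, whereas the step of a 1.6-fold higher number from compound 2 to compound 3 (0.20 log units; within the scatter) lies within the scatter, so compound 2 and compound 3 cannot be told apart.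

Compound 4 `CCn1c(C(=O)OCc2ccccn2)ccc1C(CC)(CC)c1ccc(OCC(=O)C(C)(C)C)c(C)c1` differs from compound 3 by (pyridin-2-yl)methyl in place of 4-(ethoxycarbonyl)phenyl on an oxygen next to a carbonyl group. The step of a 1.6-fold higher number from compound 2 to compound 3 (0.20 log units; within the scatter) bears most directly on this change, for it too exchanged the group on the oxygen next to the carbonyl and produced no step beyond the scatter. The steps of a 240-fold higher number from compound 1 to compound 2 (2.38 log units; beyond the scatter) and a 380-fold higher number from compound 1 to compound 3 (2.58 log units; beyond the scatter) concern the loss of the (2-aminoethyl)amino group, which compound 4 also lacks. In this assay compound 4 is therefore expected to move little, with a 1.5-fold lower number from compound 3 to compound 4 (0.18 log units; within the scatter) as the estimated step. Compound 4 is estimated at 30000 nM, within an expected range of 8000 nM to 100000 nM.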

Compound 4, half-maximal effective concentration: > 50000 nM
Compound 4 ended at the assay's limit; the forecaster's own chance of this, stated with the estimate: 10%; middle value at least 1.6-fold (0.22 log units) from the limit.
By their numbers in this assay, from the lowest: compound 1; then compounds 2 and 3 (each within the scatter of the next). At a limit, above all of these: compound 4.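

In this assay compound 4 gives > 50000 nM, which is a limit of the assay and not a number: the limit of > 50000 nM in this assay, at which 1 of the 4 values shown sits.

With that limit, the steps of an at least 1.0-fold higher number from compound 3 to compound 4 (0.04 log units; that floor lies within the scatter) and an at least 1.7-fold higher number from compound 2 to compound 4 (0.23 log units; that floor lies within the scatter) give only floors within the scatter, so (pyridin-2-yl)methyl on an oxygen next to a carbonyl group can be neither ranked against nor told apart from the two groups measured earlier in that place. The remaining step, an at least 410-fold higher number from compound 1 to compound 4 (2.61 log units; beyond the scatter), is large and adds something new: a six-membered aromatic ring with a hetero atom on this oxygen still leaves the number far from that of the (2-aminoethyl)amino compound, and none of the three groups attached through oxygen goes against this.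

The compounds shown leave open how far above the limit compound 4 actually lies. They also leave open which part of the (2-aminoethyl)amino group goes with the lower number, since a plain ethylamino amide, a (2-aminoethyl)oxy group or a free carboxylic acid on the same carbonyl carbon would separate the amide nitrogen from the terminal amine.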